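Nitro in place of methyl: expectation for compound 4

A few compounds are considered here, and "the series" means these few. Any claim that something is new, unique, unknown or untested is made for them only; others in the source may bear on it.

Compound 1 `Cc1ccccc1NC(=S)N/N=C/c1ccc(O)cc1`, compound 2 `Cc1ccc(NC(=S)N/N=C/c2ccc(O)cc2)cc1` and compound 3 `O=[N+]([O-])c1ccccc1NC(=S)N/N=C/c1ccc(O)cc1` are the measured members of the series. In an assay for inhibition of ribonucleoside-diphosphate reductase RR1 (Homo sapiens), with a stated time of 30 min (on this read-out higher numbers stand for weaker inhibition and lower numbers for stronger inhibition), compound 1 gives 36500 nM. In this assay compound 2 gives 14200 nM, the lowest of the three numbers, and compound 3 gives 39300 nM. Compound 1 and compound 3 differ in one place, (nitro in place of methyl on an aromatic carbon), and the step is a 1.1-fold higher number from compound 1 to compound 3 (0.03 log units; within the scatter). Compound 2 has the same atoms as compound 1 joined differently; the difference between the two cores is not broken down here. Compound 4 `O=[N+]([O-])c1ccc(NC(=S)N/N=C/c2ccc(O)cc2)cc1` is not yet measured. It stands to compound 2 as compound 3 stands to compound 1, (nitro in place of methyl on an aromatic carbon); in compound 4 the place is para to a large group, whereas in compound 3 it is ortho to a large group, so this is the same kind of change, not the same change. Going by the values given here, the expected step of a 1.1-fold higher number from compound 2 to compound 4 (0.05 log units; within the scatter) is set beside the measured one, because the step of a 1.1-fold higher number from compound 1 to compound 3 (0.03 log units; within the scatter) is the only measured instance of this change here. Compound 4 is accordingly estimated at 16000 nM, with a likely span from 7000 nM to 36000 nM.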

Compound 4, half-maximal inhibitory concentration: 45100 nM
Beside the measured number, compound 4's estimate is 2.8-fold (0.45 log units) below it; the measured number lies above the stated range.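

In this assay, nitro in place of methyl on an aromatic carbon gives a 3.2-fold higher number from compound 2 to compound 4 (0.50 log units; beyond the scatter), so the change does not carry over at one size from one core to the other: the same change on two cores in this assay, a 1.1-fold higher number (0.03 log units; within the scatter) from compound 1 to compound 3 and a 3.2-fold higher number (0.50 log units; beyond the scatter) from compound 2 to compound 4, 2.9-fold (0.47 log units) apart, beyond the scatter of two such steps

The two steps also differ in more than the core, since the nitro of compound 4 is para to a large group while that of compound 3 stands at another place on the ring, and core and place cannot be told apart with this pair. What the steps show is that a result for this change on one compound is a poor guide to its size on another in this series; they do not show why the steps differ, and they give no rule for any further core.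

Open, going by these compounds, is whether an amine or a carboxylic acid on the same aromatic carbon would also separate the two cores. Also open, on these data alone, is whether a single group such as chloro, set at each place in turn on one core, would show any difference in the read-out.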